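The source may report more compounds than this note shows. Statements on the series, on what has been measured and on what is new or still open speak of the compounds shown alone.

Values in a functional assay on HeLa cells (Homo sapiens) for inhibition, read by CCK-8 assay, with a stated time of 48 h; on this read-out lower numbers stand for stronger inhibition and higher numbers for weaker inhibition:

compound 1 `COc1cc(-c2ccnc3cc(-c4ccc(C(C)=O)cc4)nn23)cc(OC)c1OC`: 1810 nM
compound 2 `COc1cc(-c2ccnc3cc(-c4ccc(-c5cnn(C)c5)cc4)nn23)cc(OC)c1OC`: 1830 nM
compound 3 `CCOC(=O)c1ccc(-c2cc3nccc(-c4cc(OC)c(OC)c(OC)c4)n3n2)cc1`: only a limit of the assay, > 10000 nM

Compound 1 and compound 2 sit within the scatter of each other, as a 1.0-fold higher number from compound 1 to compound 2 (0.00 log units; within the scatter) shows. Compound 3 sits at the limit (the limit of > 10000 nM in this assay, at which 1 of the 3 values shown sits). Both an at least 5.5-fold higher number from compound 1 to compound 3 (0.74 log units; beyond the scatter) and an at least 5.4-fold higher number from compound 2 to compound 3 (0.73 log units; beyond the scatter) are beyond the scatter.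

Compound 4 `COc1cc(-c2ccnc3cc(-c4cn(C)c5ccccc45)nn23)cc(OC)c1OC` differs from compound 1 in that (1-methyl-1H-indol-3-yl in place of 4-acetylphenyl on an aromatic carbon). Within the data shown here, no measured step covers this change directly. The closest is a 1.0-fold higher number from compound 1 to compound 2 (0.00 log units; within the scatter), where 1-methyl-1H-pyrazol-4-yl in place of acetyl on an aromatic carbon left the number unchanged; the change to compound 4 is larger, since the whole 4-acetylphenyl leaves and 1-methyl-1H-indol-3-yl enters in its place. The steps to compound 3 concern the ethoxycarbonyl group and do not bear on this change. For compound 4 a step of about a 1.4-fold higher number from compound 1 to compound 4 (0.14 log units; within the scatter) is therefore expected, that is, nothing beyond the scatter, though with wide uncertainty. Compound 4 is estimated at 2500 nM, with a range from 800 nM to 8000 nM.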

Compound 4, half-maximal inhibitory concentration: 399 nM
Compound 4: middle estimate off by 6.3-fold (0.80 log units), on the high side; measured number outside the range, below it.
By their numbers in this assay, from the lowest: compound 4; then compounds 1 and 2 (each within the scatter of the next). At a limit, above all of these: compound 3.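

In this assay this carbon of the five-membered aromatic ring with 2 nitrogen accepts loss of the whole 4-acetylphenyl: 1-methyl-1H-indol-3-yl in its place gives a 4.5-fold lower number from compound 1 to compound 4 (0.66 log units; beyond the scatter) and so moves the number beyond the scatter in the direction of stronger inhibition. The earlier steps all kept the phenyl ring and changed only its substituent, and none of them lowered the number, so the phenyl ring is now shown not to be required here. No measured information shown bears on what lies behind this step.

Open, going by these compounds, is whether the step belongs to the five-membered or the six-membered ring of the indole, as both enter together. Also open, on these data alone, is how a longer chain in place of the methyl of 1-methyl-1H-indol-3-yl, or an amine on the indole, would read in this assay.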